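Chloro on the phenyl ring of a pyridylmethylene thiazolidinone

The source may hold more compounds than are shown below. What is called first, only, known or untested is meant among the compounds shown, and "the series" means these compounds.

Compound 1 `O=C1N/C(=N/c2ccccc2)S/C1=C\c1ccccn1`: 29.2%
Compound 2 `Cc1cccc(C)c1/N=C1/NC(=O)/C(=C/c2ccccn2)S1`: 51.5%

Of the compounds shown here, two have been tested in a functional assay on the whole organism (strain Swiss albino) for inhibition, with Mus musculus as the target, in the writhing test, with stated times of 30 min and 15 min, at a dose of 50 mg/kg by the oral route; a lower number here means less inhibition, a higher number more inhibition at the dose given (going by the name of the read-out). Compound 1 gives 29.2% in this assay, and compound 2 gives 51.5%. Compound 1 thus stands lowest of the two numbers; its nearest neighbour, compound 2, lies higher by a margin beyond the usual scatter of repeated measurements. Within the data shown here, no pair of the measured compounds differs in one place only, so the two values show only that the more substituted phenyl ring goes with the larger inhibition.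

Compound 3 `O=C1N/C(=N/c2ccccc2Cl)S/C1=C\c1ccccn1` has not yet been measured. It differs from compound 1 by chloro in place of hydrogen on an aromatic carbon, the place being on an aromatic carbon of a six-membered aromatic ring of carbon only. Among the measured compounds shown here, with no single-change step in hand, the size of the step in this assay cannot be read from the data; the higher number of compound 2, 51.5%, is the only hint that substitution on that ring may help. For compound 3 a modest rise from compound 1 is expected, a number 10.8 percentage points higher from compound 1 to compound 3 (beyond the scatter), though a step within the scatter is possible. The estimate for compound 3 is 40%, with a range from 25% to 58%.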

Compound 3, a percentage reported as inhibition, in the whole organism at one dose (the size of the read-out at that dose, not a potency): 36.2%
For compound 3 the middle estimate is 3.8 percentage points above the measured one; low and high end bracket the measured number.
By their numbers in this assay, from the lowest: compounds 1 and 3 (each within the scatter of the next); then compound 2.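

Among these compounds, this gives the first single-change step: in this assay, chloro in place of hydrogen on an aromatic carbon, ortho to a large group, moves the number a number 7 percentage points higher from compound 1 to compound 3 (within the scatter). At this position, then, the change from phenyl to 2-chlorophenyl does not separate compound 3 from compound 1 in this oral writhing read-out at the one dose used, so a single chloro here cannot be counted as a gain or a loss in inhibition. Nothing available bears on why the step is this size.

Among the compounds shown here, the value of compound 2, 51.5%, cannot be traced to any single change, since no step linking it to compound 1 or compound 3 can be read, and how much its methyl groups contribute stays unknown. Also open, going by these compounds, is whether a single methyl, a methoxy group, an amine or a carboxylic acid in place of that same hydrogen, or chloro on another carbon of the phenyl ring, would give a step beyond the scatter.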